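Cyano in Place of a Three-Atom Group on the Fused Ring

This account rests on a few compounds, and the source may have more. Where it says the series, first, only, none or still open, it means among the compounds named here.

Compound 1: `Cc1ccc2c(Cc3nn4c(C=O)c(-c5ccc(Cl)cc5)nc4s3)coc2c1` — 42.5%
Compound 2: `Cc1ccc2c(Cc3nn4c(/C=N/O)c(-c5ccc(Cl)cc5)nc4s3)coc2c1` — 10%

In a functional assay on the whole organism (strain Wistar albino) for inhibition, with Rattus norvegicus as the target, read by paw edema, with a stated time of 3 h, at a dose of 100 mg/kg by the oral route (on this read-out higher numbers stand for more inhibition at the one dose given (going by the name of the read-out) and lower numbers for less inhibition), compound 1 gives 42.5%, while compound 2 gives 10%. For the measured compounds named here, compound 2 thus holds the lowest of the two numbers, and the single measured step, a number 32.5 percentage points lower from compound 1 to compound 2 (beyond the scatter), separates it from compound 1. Compound 3, `Cc1ccc2c(Cc3nn4c(C#N)c(-c5ccc(Cl)cc5)nc4s3)coc2c1`, has not been measured in this assay. It differs from compound 2 by a group of 2 heavy atoms (1 carbon, 1 nitrogen; no ring) in place of a group of 3 heavy atoms (1 carbon, 1 nitrogen, 1 oxygen; no ring), on an aromatic carbon. Going by the values given here, the only step that bears on this change is the one from compound 1 to compound 2, which took place on the same aromatic carbon and was large; the move to compound 3 again removes the group of 3 heavy atoms from that position, but puts cyano there rather than restoring the group of 2 heavy atoms, and no measured compound carries cyano. The step of a number 20 percentage points higher from compound 2 to compound 3 (beyond the scatter) is therefore expected to run upward, with wide uncertainty. For compound 3 the value is estimated at 30%, within a range from 10% to 50%.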

Compound 3, a percentage reported as inhibition, in the whole organism at one dose (the size of the read-out at that dose, not a potency): 43.4%
The estimate for compound 3 lay 13.4 percentage points below the measured number; low and high end bracket the measured number.
By their numbers in this assay, from the lowest: compound 2; then compounds 1 and 3 (each within the scatter of the next).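

In this assay, the aromatic carbon proves able to carry a group other than formyl without a lower number: replacing the group of 3 heavy atoms with cyano gives a number 33.4 percentage points higher from compound 2 to compound 3 (beyond the scatter). Cyano and formyl cannot be told apart here, with a number 0.9 percentage points higher from compound 1 to compound 3 (within the scatter), so the low number of compound 2 belongs to the group of 3 heavy atoms among the three compounds, not to every change away from formyl. Nothing measured explains why these groups differ as they do.

The three compounds do not show whether the hydrogen-bond donor counted on the group of 3 heavy atoms has anything to do with its low number, since that group also differs from cyano in its atoms and bonds. They also leave open whether a carboxylic acid, a primary amide or an aminomethyl group on the same carbon would stand with compound 1 and compound 3 or with compound 2, and whether any group there could give a higher number than these two.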